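Adding a butyl chain to the phenyl arm of compound 2

This account rests on a few compounds, and the source may have more. Where it says the series, first, only, none or still open, it means among the compounds named here.

Three compounds share one core and differ only in the arm attached to it. Compound 1 `CCCCCc1cc(-c2cn([C@H]3C[C@H](OC(C)=O)[C@@H](COC(C)=O)O3)c(=O)[nH]c2=O)on1` carries a pentyl chain; in a functional assay on NUGC-3 cells (Homo sapiens) for cytotoxicity, read by sulforhodamine B assay, tested at 10 uM (a lower number here means less inhibition, a higher number more inhibition at the concentration tested (going by the name of the read-out)), compound 1 gives 91.9%. Compound 2 `CC(=O)OC[C@H]1O[C@@H](n2cc(-c3cc(-c4ccccc4)no3)c(=O)[nH]c2=O)C[C@@H]1OC(C)=O` carries a phenyl in its place, and in this assay compound 2 gives 87.6%. Compound 3 `CC(=O)OC[C@H]1O[C@@H](n2cc(-c3cn(Cc4ccccc4)nn3)c(=O)[nH]c2=O)C[C@@H]1OC(C)=O` has a different arm again, and in this assay compound 3 gives 88.7%. The three values sit close together: the step of a number 4.3 percentage points lower from compound 1 to compound 2 (within the scatter) lies within the scatter, and the gap between compound 2 and compound 3 is even smaller, so compound 2 cannot be set apart from either neighbour.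

Compound 4 `CCCCc1ccc(-c2cc(-c3cn([C@H]4C[C@H](OC(C)=O)[C@@H](COC(C)=O)O4)c(=O)[nH]c3=O)on2)cc1` keeps the phenyl of compound 2 and adds to it: butyl in place of hydrogen on an aromatic carbon. Going by the values given here, the only measured step that touches the arm, from compound 1 to compound 2, was within the scatter, and all three measured numbers are high, so no shift beyond the scatter is expected from adding a butyl chain. Compound 4 is therefore expected to give about 90%, between 80% and 97%, which means an expected step of a number 2.4 percentage points higher from compound 2 to compound 4 (within the scatter).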

Compound 4, a percentage reported as inhibition, at one concentration (the size of the read-out at that concentration, not a potency): 39.8%
Compound 4: the middle estimate sits 50.2 percentage points above what was measured, and the stated range ends above it.
By their numbers in this assay, from the lowest: compound 4; then compounds 2, 3 and 1 (each within the scatter of the next).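

In this assay, pentyl and phenyl on the arm could not be told apart, but the butyl group on the phenyl shows that this part of the molecule is not indifferent to change: the result is a number 47.8 percentage points lower from compound 2 to compound 4 (beyond the scatter). Set against the pentyl arm, the reading is the same, a number 52.1 percentage points lower from compound 1 to compound 4 (beyond the scatter). A carbon chain alone therefore does not go with a low number, since compound 1 also carries one; here the drop goes with the whole 4-butylphenyl arm.

No measurement at hand explains this drop. On these data alone, it remains open whether a shorter chain such as methyl in the same place on the phenyl, or an amine or a carboxylic acid there, would keep the number high.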